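Removing the Methyl from the Ether Oxygen of Compound 2

The compounds below may be only part of what the source reports. "The series", "measured", "known", "first", "only" and "open" are said of these compounds alone.

Measured compounds:
Compound 1 `COc1cc(C)cc(-c2c(-c3ccnc(-c4ccc(N(C)C)cc4)c3)cnn2CC#N)c1` — in a functional assay on U-251 cells (Homo sapiens) for inhibition, read by sulforhodamine B assay, with a stated time of 48 h (a higher number here means that more compound is tolerated, a lower number that less compound is tolerated), compound 1 gives > 100000 nM, a limit of the assay, not a number.
Compound 2 `COc1cc(C)cc(-c2nn(CC#N)cc2-c2ccnc(-c3ccc(N(C)C)cc3)c2)c1` — in this assay compound 2 gives > 100000 nM, again a limit of the assay.
Compound 3 `COc1cc(C)cc(-c2nn(CC#N)cc2-c2ccc(-c3cccc(C(C)=O)c3)nc2)c1` — in this assay compound 3 gives > 100000 nM, also a limit of the assay.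

Compound 2 thus stands at the limit of > 100000 nM in this assay, at which 3 of the 3 values shown sit. For the measured compounds named here, none of the three compounds produced a measurable number, so no step between measured compounds can be drawn, and nothing is known about how far apart they really lie.

Compound 4 `Cc1cc(O)cc(-c2nn(CC#N)cc2-c2ccnc(-c3ccc(N(C)C)cc3)c2)c1` has not yet been tested. It differs from compound 2 in one place: hydrogen in place of methyl on an oxygen on an aromatic ring. The change from methoxy to hydroxy swaps a 3-methoxy-5-methylphenyl for a 3-hydroxy-5-methylphenyl, and all else stays the same.

With every measured compound sitting at the assay limit, the expectation for the step from compound 2 to compound 4 is none beyond the scatter, as a number no higher from compound 2 to compound 4 (the limit leaves the size open) expresses. Compound 4 is therefore expected to give about 100000 nM in this assay, within a range from 40000 nM to 250000 nM, most likely reported again only as a limit.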

Compound 4, concentration lethal to 50% of the cells: 61300 nM
Beside the measured number, compound 4's estimate is 1.6-fold (0.21 log units) above it; low and high end bracket the measured number.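

For the compounds shown here, compound 4 gives the first value in this set that is a number and not a limit: in this assay compound 4 gives 61300 nM, and this comes from nothing more than hydrogen in place of methyl on the oxygen of the 3-methoxy-5-methylphenyl. So this oxygen is a place where a single small change can bring the read-out into the measurable range, and going from methoxy to hydroxy gives an at least 1.6-fold lower number from compound 2 to compound 4 (0.21 log units; that floor lies within the scatter), although that smallest possible size does not by itself clear the usual scatter. On these data alone, the true size of the step stays unknown because compound 2 is a limit and not a number: the limit of > 100000 nM in this assay, at which 3 of the 4 values shown sit.

The compounds shown leave open whether the same change from methoxy to hydroxy would also give a measurable number on the cores of compound 1 and compound 3. They also leave open what other groups would do at this place on the ring, such as an amine, a carboxylic acid or a longer ether chain like ethoxy, so the effect cannot yet be called a trend.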